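The source may hold more compounds than are shown below. What is called first, only, known or untested is meant among the compounds shown, and "the series" means these compounds.

In an assay on isolated protein for inhibition of phosphatidylinositol 4,5-bisphosphate 3-kinase catalytic subunit beta isoform (Homo sapiens), read by 33P incorporation, with a stated time of 60 min (on this read-out lower numbers stand for stronger inhibition and higher numbers for weaker inhibition), compound 1 `Cc1ccc([N+](=O)[O-])cc1S(=O)(=O)N(C)/N=C/c1cnn2ccccc12` reaches only a limit, > 10000 nM, and so has no measured number of its own. Two compounds carry a substituent in place of hydrogen on an aromatic carbon of the shared core. Compound 2 `COC(=O)c1ccn2ncc(/C=N/N(C)S(=O)(=O)c3cc([N+](=O)[O-])ccc3C)c2c1` is reported as a limit as well, > 1000 nM. Compound 3 `Cc1ccc([N+](=O)[O-])cc1S(=O)(=O)N(C)/N=C/c1cnn2ccc(C(N)=O)cc12` likewise stops at a limit, > 1000 nM. The step that the two limits leave unreadable from compound 1 to compound 2 and the step that the two limits leave unreadable from compound 1 to compound 3 cannot be sized, since both ends are limits, and the step that the two limits leave unreadable from compound 2 to compound 3 is equally unreadable. The evidence is thin: the limit of > 1000 nM in this assay, at which 2 of the 3 values shown sit, and (the limit of > 10000 nM in this assay, at which 1 of the 3 values shown sits). Compound 4 `Cc1ccc([N+](=O)[O-])cc1S(=O)(=O)N(C)/N=C/c1cnn2ccc(C(=O)N(C)C)cc12` differs from compound 1 by dimethylcarbamoyl in place of hydrogen on an aromatic carbon. The measured steps that bear on it, those from compound 1 to the two substituted compounds, show no readable size, so no gain beyond the scatter can be drawn from them in this assay. Compound 4 is therefore expected to remain at or near a limit, and the step that the limit leaves unreadable from compound 1 to compound 4 is expected to show no readable change. Compound 4 is estimated at 20000 nM, within a range from 3000 nM to 100000 nM.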

Compound 4, half-maximal inhibitory concentration: > 1000 nM
Compound 4: a limit, no number; the forecaster's own chance of this, stated with the estimate: 85%; the middle value is on the limit's open side.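

In this assay compound 4 ends at a limit, as do compound 1, compound 2 and compound 3, so none of the steps to compound 4 can be read: the limit of > 1000 nM in this assay, at which 3 of the 4 values shown sit. The compounds shown leave open whether any substituent at this place on the shared core changes the inhibition at all.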